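A few compounds are considered here, and "the series" means these few. Any claim that something is new, unique, unknown or untested is made for them only; others in the source may bear on it.

Measured compounds:
- compound 1 `Cc1c(OCCCCOc2ccccc2C(=O)O)ccc(C(=O)CC2CCCC2)c1C` — 2580 nM
- compound 2 `Cc1c(OCCCCOc2cccc(C(=O)O)c2)ccc(C(=O)CC2CCCC2)c1O` — 451 nM
- compound 3 `Cc1c(OCCCCOc2cccc(C(=O)O)c2)ccc(C(=O)CC(C)C)c1C` — "not active" (no number reported), no number

In an assay on HEK293 cells for positive allosteric modulation of metabotropic glutamate receptor 2 (Rattus norvegicus), read by thallium flux, with a stated time of 2.5 min (on this read-out higher numbers stand for an effect only at larger amounts of compound and lower numbers for an effect already at smaller amounts), compound 3 is reported as "not active" (no number reported) and gave no measurable response, so it stands below every compound here that returned a value; there is no number to place it against. Compound 1 gives 2580 nM and compound 2 gives 451 nM, and both of these carry the (cyclopentylmethyl)carbonyl group, whereas compound 3 carries the isobutylcarbonyl group.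

Compound 4 `Cc1c(OCCCCOc2cccc(C(=O)O)c2)ccc(C(=O)CC2CCCC2)c1C` is not yet measured. It differs from compound 3 by cyclopentyl in place of isopropyl on a saturated chain carbon bound to a carbonyl carbon. This is the same chain that compound 1 and compound 2 carry, and both of those returned numbers where compound 3 returned none. The step from compound 3 to compound 4 is therefore expected to turn an inactive compound into an active one, a change well beyond the usual scatter, though its size cannot be stated since compound 3 has no value.

For compound 4 in this assay the estimated value is 700 nM, with a range from 150 nM to 3500 nM. This estimate rests on compound 2 with 451 nM and compound 1 with 2580 nM, which bracket the likely outcome; a report of no activity remains possible.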

Compound 4, half-maximal effective concentration: "not active" (no number reported)
For compound 4 the study gives words and no number; no gap can be computed for the estimate.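

In this assay, compound 4 is reported as not active, as is compound 3, so with no number on either side no step can be read between them. No measured evidence bears on this result. The compounds shown leave open whether cyclopentyl in place of isopropyl changes this read-out at all.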